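Aryl swap on the sulfonamide sulfur: compound 2 to compound 3

The compounds below may be only part of what the source reports. "The series", "measured", "known", "first", "only" and "open" are said of these compounds alone.

Two compounds sharing one core carry different aryl groups on the sulfonyl sulfur. Compound 1 `COc1ccc(S(=O)(=O)N(C)c2ccc3[nH]c(-c4n[nH]c5ccccc45)cc3n2)cc1` gives 4340 nM in a functional assay on HL-60 cells (Homo sapiens) for antiproliferative activity, read by MTT assay, with a stated time of 72 h; a higher number here means a weaker inhibitor, a lower number a stronger inhibitor. Compound 2 `CN(c1ccc2[nH]c(-c3n[nH]c4ccccc34)cc2n1)S(=O)(=O)c1cccc([N+](=O)[O-])c1` gives 3660 nM in this assay. Compound 2 holds the lower of the two numbers, but the step of a 1.2-fold lower number from compound 1 to compound 2 (0.07 log units; within the scatter) lies within the scatter, so no order between the two can be claimed.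

Compound 3 `CN(c1ccc2[nH]c(-c3n[nH]c4ccccc34)cc2n1)S(=O)(=O)c1ccc(OC(F)(F)F)cc1` differs from compound 2 in one place: 4-(trifluoromethoxy)phenyl in place of 3-nitrophenyl on a sulfonyl sulfur. Going by the values given here, the only measured step that bears on this change is the exchange of one aryl group for another on the same sulfonyl sulfur, a 1.2-fold lower number from compound 1 to compound 2 (0.07 log units; within the scatter), which did not move the number beyond the scatter. The expectation for compound 3 is therefore a step of a 1.1-fold higher number from compound 2 to compound 3 (0.04 log units; within the scatter) in this assay, with no change beyond the scatter. Compound 3 is estimated at 4000 nM in this assay, within a range of 1500 nM to 11000 nM.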

Compound 3, half-maximal inhibitory concentration: 1170 nM
The estimate for compound 3 lay 3.4-fold (0.53 log units) above the measured number; the measured number lies below the stated range.
By their numbers in this assay, from the lowest: compound 3; then compounds 2 and 1 (each within the scatter of the next).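

In this assay the aryl group on the sulfonyl sulfur proved able to move the number beyond the scatter (a 3.1-fold lower number from compound 2 to compound 3 (0.50 log units; beyond the scatter)), which the exchange between the first two aryl groups did not show. The change can also be confined to a single substituent: trifluoromethyl in place of methyl on an oxygen on an aromatic ring, with the rest of the molecule unchanged, gives a step of similar size (a 3.7-fold lower number from compound 1 to compound 3 (0.57 log units; beyond the scatter)). No measurement is available that accounts for either step.

As far as these compounds go, it remains open whether the trifluoromethyl group needs the oxygen, since a trifluoromethyl or a chlorine placed directly on the phenyl ring would separate the two. An unsubstituted phenyl, or a phenyl carrying an amine or a carboxylic acid, would show how far this position tolerates other groups.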